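Methoxyphenyl Positional Switch on the Saturated Ring Carbon

A few compounds are considered here, and "the series" means these few. Any claim that something is new, unique, unknown or untested is made for them only; others in the source may bear on it.

Compound 1 `CC1=C(C(=O)Nc2ccccc2Cl)C(c2ccc(Cl)cc2)NC(=O)N1` and compound 2 `CC1=C(C(=O)Nc2ccccc2Cl)C(c2ccc([N+](=O)[O-])cc2)NC(=O)N1` share the core of compound 3 and in an ADME assay on Vero cells (Chlorocebus sabaeus) for cytotoxicity, read by XTT assay, with a stated time of 72 h (on this read-out higher numbers stand for lower toxicity in this test and lower numbers for higher toxicity in this test), are recorded as follows: compound 1 gives "non-toxic" (no number reported) and compound 2 gives "non-toxic" (no number reported), each reported without a number. Compound 3 `COc1cccc(C2NC(=O)NC(C)=C2C(=O)Nc2ccccc2Cl)c1` in this assay gives > 100000 nM, which is a limit of the assay rather than a number, as the evidence the limit of > 100000 nM in this assay, at which 1 of the 3 values shown sits, shows. Within the data shown here, compound 3 therefore stands at the limit, with nothing above or below it as a measured number, so no step between measured compounds is available.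

Compound 4 `COc1ccc(C2NC(=O)NC(C)=C2C(=O)Nc2ccccc2Cl)cc1` differs from compound 3 in one place: 4-methoxyphenyl in place of 3-methoxyphenyl on a saturated ring carbon. Among the measured compounds shown here, the three values at hand all point the same way, and no measured step in this assay suggests that this change moves the read-out beyond the scatter in either direction. Compound 4 is expected to sit at the same limit, estimated at 150000 nM with a range of 60000 nM to 500000 nM, which is expected to mean a step that the limit leaves unreadable from compound 3 to compound 4 from compound 3, none beyond the scatter.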

Compound 4, half-maximal cytotoxic concentration: > 100000 nM
Compound 4 was reported as a limit; the forecaster's own chance of this, stated with the estimate: 75%; the middle value does not contradict the limit.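

Compound 3 and compound 4 both stand at a limit in this assay, so no step between them can be read: the limit of > 100000 nM in this assay, at which 2 of the 4 values shown sit.

The compounds shown leave open whether 4-methoxyphenyl in place of 3-methoxyphenyl shifts the half-maximal cytotoxic concentration at all, and at what concentration either compound turns toxic.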